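Swapping the Ring Amine Tail on a Substance-P Receptor Blocker

The source may report more compounds than this note shows. Statements on the series, on what has been measured and on what is new or still open speak of the compounds shown alone.

Compound 1 `O=C1NC(COCc2cc(C(F)(F)F)cc(C(F)(F)F)c2)(c2ccc(F)cc2)CN1C1CCNCC1` was tested in an assay on CHO cells for displacement of a labelled ligand from Substance-P receptor (Homo sapiens) (a lower number here means a stronger inhibitor, a higher number a weaker inhibitor), and gave 0.9 nM. Among the compounds with values here, of the two compounds measured so far, compound 1 shows the lowest number. The other one, compound 2 `O=C1NC[C@@](COCc2cc(C(F)(F)F)cc(C(F)(F)F)c2)(c2ccccc2)N1`, gives 6 nM, a higher number than compound 1, and that gap lies beyond the usual scatter of the assay.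

Compound 3 `O=C1NC(COCc2cc(C(F)(F)F)cc(C(F)(F)F)c2)(c2ccc(F)cc2)CN1CCN1CCCC1` has not been measured yet. It keeps the shared core of compound 1 and changes one group: 2-(pyrrolidin-1-yl)ethyl in place of piperidin-4-yl on an amide-type nitrogen in a ring. Within the data shown here, no measured pair shows this exact change, so its effect is unknown. Both groups carry a basic ring nitrogen, which argues for a modest step from compound 1 to compound 3, and the loss of the hydrogen-bond donor slightly favours a weaker number. The expected step is a 2.0-fold higher number from compound 1 to compound 3 (0.30 log units; within the scatter). Compound 3 is therefore expected to give about 1.8 nM, within a range from 0.5 nM to 6 nM.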

Compound 3, inhibition constant: 1.6 nM
Compound 3: the middle estimate sits 1.1-fold (0.05 log units) above what was measured; the measured number falls inside the stated range.
By their numbers in this assay, from the lowest: compounds 1 and 3 (each within the scatter of the next); then compound 2.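

In this assay, the amide-type ring nitrogen accepts 2-(pyrrolidin-1-yl)ethyl in place of piperidin-4-yl with a 1.8-fold higher number from compound 1 to compound 3 (0.25 log units; within the scatter), so the two tails cannot be told apart here. This holds even though the entering group has a five-membered ring and no hydrogen-bond donors, whereas the group leaving has a six-membered ring and a hydrogen-bond donor, so that donor is not required for a number in this range. Nothing available explains why these two tails read alike.

The compounds shown leave open whether a tail with no amine at all, such as a plain ethyl group, would read the same at this position. They also leave open how a longer chain, such as 3-(pyrrolidin-1-yl)propyl, would read, and compound 2 differs from compound 1 in more than one place, so it cannot settle either question.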